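The source may hold more compounds than are shown below. What is called first, only, known or untested is meant among the compounds shown, and "the series" means these compounds.

Compound 1, with the structure `C=C1CC[C@H]2C(C)(C)CCC[C@]2(C)[C@H]1C/C=C1/C(=O)OC[C@H]1O`, was tested in a functional assay on RAW264.7 cells (Mus musculus) for inhibition, read by ELISA, with stated times of 1 h and 18 h, tested at 0.1 uM (a higher number here means a weaker effect of the compound at the concentration tested, a lower number a stronger effect), and gives 99.2%. Two relatives were measured the same way. Compound 2, `C=C1CC[C@H]2C(C)(C)CCC[C@]2(C)[C@H]1C/C=C1\CC(OC)OC1=O`, gives 101% in this assay, and compound 3, `C=C1CC[C@H]2C(C)(C)CCC[C@]2(C)[C@H]1C[C@H](O)[C@H]1C(=O)OC[C@H]1O`, gives 105%. Compound 1 sits at the lower end of these three numbers, yet its gaps to compound 2 and to compound 3 both lie within the usual scatter of such measurements, so the three cannot truly be told apart: all of them leave the read-out close to what is seen without any compound.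

Compound 4, `C=C1CC[C@H]2C(C)(C)CCC[C@]2(C)[C@H]1C/C=C1\C(=O)OC[C@H]1O`, is the next compound of interest. Compared with compound 1, (the two compounds have the same atoms and bonds and differ only in configuration as drawn: 1 of 5 stereo elements differ; a double bond is drawn E in compound 1 and Z in compound 4). Among the measured compounds shown here, no pair of measured compounds differs in one place, so there is no measured step to lean on. Given that compound 1, compound 2 and compound 3 all show no effect beyond the scatter, the expectation for this assay is a step from compound 1 to compound 4 of no size beyond the scatter, in no particular direction, namely a number 0.8 percentage points higher from compound 1 to compound 4 (within the scatter). Compound 4 is therefore estimated to give 100%, within a range from 92% to 108%.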

Compound 4, a percentage reported as activity, at one concentration (the size of the read-out at that concentration, not a potency): 101%
Estimate against measurement, compound 4: 1 percentage points below; measured number inside the range.
By their numbers in this assay, from the lowest: compounds 1, 2, 4 and 3 (each within the scatter of the next).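

Among the compounds shown here, this is the first pair that differs in one place, so the geometry of the double bond can be read directly. In this assay, changing that geometry from E to Z gives a number 1.8 percentage points higher from compound 1 to compound 4 (within the scatter). Nothing else separates the pair, so this reading concerns the double bond alone: the fact that compounds 1 and 4 differ only in the configuration as drawn.

At this single concentration, then, the E and Z forms cannot be told apart, and the geometry of this double bond shows no measurable influence on the read-out.

From the compounds shown here alone, whether the two forms would separate at a higher concentration, where a real effect might appear, remains open. So does whether an amine or a carboxylic acid added to the shared core would move the read-out at all.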